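Adding tert-butyl to the acetamido chain of compound 3

The source may report more compounds than this note shows. Statements on the series, on what has been measured and on what is new or still open speak of the compounds shown alone.

Measured in a toxicity assay on KB cells (Homo sapiens) for cytotoxicity, read by fluorescence, with a stated time of 3 days; a lower number here means that less compound is needed, a higher number that more compound is needed for the effect:
Compound 1 `CCCCOC(=O)CNC(=O)[C@H](CSc1ccc([N+](=O)[O-])cc1[N+](=O)[O-])NC(=O)CC[C@H](NC(=O)c1ccccc1)C(=O)OCCCC`: > 300 uM (a limit)
Compound 2 `CCCCOC(=O)CNC(=O)[C@H](CSc1ccc([N+](=O)[O-])cc1[N+](=O)[O-])NC(=O)CC[C@H](NC(=O)C(C)(C)C)C(=O)OCCCC`: 83.4 uM
Compound 3 `CCCCOC(=O)CNC(=O)[C@H](CSc1ccc([N+](=O)[O-])cc1[N+](=O)[O-])NC(=O)CC[C@H](NC(C)=O)C(=O)OCCCC`: > 300 uM (a limit)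

Compound 3 gives no number in this assay and stands only at the limit of > 300 uM in this assay, at which 2 of the 3 values shown sit. Compound 4 `CCCCOC(=O)CNC(=O)[C@H](CSc1ccc([N+](=O)[O-])cc1[N+](=O)[O-])NC(=O)CC[C@H](NC(=O)CC(C)(C)C)C(=O)OCCCC` differs from it by tert-butyl in place of hydrogen on a saturated chain carbon bound to a carbonyl carbon, which turns the acetamido into (neopentylcarbonyl)amino.

Within the data shown here, no measured step makes this exact change, but two steps bear on it by changing the group on the same carbonyl carbon. Tert-butyl in place of phenyl gave an at least 3.5-fold lower number from compound 1 to compound 2 (0.55 log units; beyond the scatter), and methyl in place of tert-butyl gave an at least 3.5-fold higher number from compound 2 to compound 3 (0.55 log units; beyond the scatter). Only compound 2 reaches a number, and in compound 2 the tert-butyl stands directly on the carbonyl carbon. Compound 4 carries it on the chain carbon instead, so the comparison is loose. Compound 1 also shows that a larger group does not always bring a number.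

A lower number than that of compound 3 is therefore expected, of at least modest size, with a real chance that compound 4 also stays at the limit. The expected step is an at least 2.7-fold lower number from compound 3 to compound 4 (0.43 log units; beyond the scatter). For compound 4 the estimated value is 110 uM, with an expected range from 40 uM to 300 uM.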

Compound 4, concentration for half-maximal effect: 250 uM
The estimate for compound 4 lay 2.3-fold (0.36 log units) below the measured number, within the range that was stated.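

In this assay, exchanging the tert-butyl on the carbonyl carbon for a neopentyl gave a 3.0-fold higher number from compound 2 to compound 4 (0.48 log units; beyond the scatter), so this position responds to where the tert-butyl stands and not only to its presence in the group. Tert-butyl in place of hydrogen on a saturated chain carbon bound to a carbonyl carbon does give compound 4 a measured number, but the step reads only as an at least 1.2-fold lower number from compound 3 to compound 4 (0.07 log units; that floor lies within the scatter), and exchanging the phenyl on the carbonyl carbon for a neopentyl reads as an at least 1.2-fold lower number from compound 1 to compound 4 (0.07 log units; that floor lies within the scatter). Neither of these two steps shows a change beyond the scatter, since compound 1 and compound 3 each stand only at a limit: the limit of > 300 uM in this assay, at which 2 of the 4 values shown sit.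

On these data alone, how far the true numbers of compound 1 and compound 3 lie from that of compound 4 stays open. Also open, as far as these compounds go, is whether an isopropyl group or a cyclohexyl ring on the same carbonyl carbon would fall nearer to compound 2 or to compound 4, and whether an amine or a carboxylic acid on the saturated chain carbon would reach a number at all.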